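A few compounds are considered here, and "the series" means these few. Any claim that something is new, unique, unknown or untested is made for them only; others in the source may bear on it.

Within the data shown here, compound 1 `Cc1nc(N)sc1CCCN/C(N)=N/C(=S)NC(c1ccccc1)c1ccccc1` is the first of the two measured compounds; in a functional assay on Right cardiac atrium for agonist activity at histamine H2 receptor (Cavia porcellus), with a stated time of 30 min, in the presence of a further agent that is not named here (on this read-out higher numbers stand for larger maximal responses and lower numbers for smaller maximal responses), compound 1 gives 0.67. Compound 2 `CCCCCNC(=O)/N=C(\N)NCCCc1sc(N)nc1C` is the second, and in this assay compound 2 gives 0.78. Among the measured compounds shown here, compound 2 thus stands highest of the two numbers so far, its gap to compound 1 lying beyond the usual scatter of repeated measurements.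

Compound 3 `Cc1nc(N)sc1CCCN/C(N)=N/C(=O)N[C@@H](C)c1ccccc1` has not yet been measured in this assay. It differs from compound 2 in a single place: 1-phenylethyl in place of pentyl on an amide-type nitrogen. For the measured compounds named here, no pair of measured compounds differs in exactly this way, so nothing directly shows the size of such a step. The only other point of reference is compound 1, which carries two aromatic rings on its tail and gives the lower value 0.67; that is a loose guide at best. The step expected here, a number 0.080 lower from compound 2 to compound 3 (within the scatter), is a small one downward, at about the edge of the scatter, and it could equally turn out to be none at all. For compound 3 the estimated value in this assay is 0.7, with a range from 0.55 to 0.85.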

Compound 3, intrinsic activity: the largest response reached, as a fraction of the reference agonist's: 1.08
Compound 3: the middle estimate sits 0.38 below what was measured, outside the stated range (above it).
By their numbers in this assay, from the lowest: compound 1; then compound 2; then compound 3.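

In this assay, a number 0.30 higher from compound 2 to compound 3 (beyond the scatter) comes with 1-phenylethyl in place of pentyl on the amide-type nitrogen, showing that the group at this position can change the maximal response by more than the usual scatter. The earlier compounds shown here offered no single-place change at this nitrogen, and this one shows that a group with a six-membered aromatic ring and a defined stereocentre is accepted there with a gain rather than a loss: compound 3 gives 1.08, about the whole of the reference agonist's response. Nothing among the data given explains why this exchange raises the response.

This single step changes several features at once, so it does not separate the contribution of the aromatic ring from that of the branched carbon, its stereocentre or the larger size of the group. On these data alone, how the mirror-image form of 1-phenylethyl, a benzyl group, a hexyl chain or a pentyl chain carrying an amine would stand on the same nitrogen remains open.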